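The source may hold more compounds than are shown below. What is called first, only, known or untested is meant among the compounds shown, and "the series" means these compounds.

Compound 1 `CN(C)C(=O)c1cc2cnc(Nc3ccc(NC(=O)C4(C(=O)Nc5ccccc5)CC4)cc3)nc2n1C1CCCC1` gives 52.8% in a functional assay on T47D cells (Homo sapiens) for inhibition, read by CCK-8 assay, with a stated time of 72 h, tested at 1 uM; on this read-out lower numbers stand for less inhibition of growth and higher numbers for more inhibition of growth at the one concentration tested.
Compound 2 `CN(C)C(=O)c1cc2cnc(Nc3ccc(NC(=O)C4(C(=O)Nc5ccccc5F)CC4)cc3)nc2n1C1CCCC1` gives 85.2% in this assay.
Compound 3 `CN(C)C(=O)c1cc2cnc(Nc3ccc(NC(=O)C4(C(=O)Nc5cccc(Br)c5)CC4)cc3)nc2n1C1CCCC1` gives 29.1% in this assay.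

Among these three, compound 3 stands lowest. The gap to its nearest neighbour is a number 23.7 percentage points lower from compound 1 to compound 3 (beyond the scatter), and the gap to the furthest is a number 56.1 percentage points lower from compound 2 to compound 3 (beyond the scatter). Compound 4 `CN(C)C(=O)c1cc2cnc(Nc3ccc(NC(=O)C4(C(=O)Nc5ccc(Cl)cc5)CC4)cc3)nc2n1C1CCCC1` differs from compound 3 in one place: 4-chlorophenyl in place of 3-bromophenyl on an amide-type nitrogen.

All three measured steps touch the same phenyl ring on the amide-type nitrogen, and all of them are beyond the scatter: a number 32.4 percentage points higher from compound 1 to compound 2 (beyond the scatter), a number 23.7 percentage points lower from compound 1 to compound 3 (beyond the scatter) and a number 56.1 percentage points lower from compound 2 to compound 3 (beyond the scatter). Among the measured compounds shown here, they show that what sits on this ring strongly sets the read-out, yet none of the measured compounds carries 4-chlorophenyl, so the new ring has no direct precedent. Removing the bromo is expected to lift the number back toward compound 1, because a number 23.7 percentage points lower from compound 1 to compound 3 (beyond the scatter) was a drop when bromo replaced hydrogen, but the chloro may pull in either direction. Compound 4 is therefore expected to give about 45% in this assay, between 20% and 75%. The expected step of a number 15.9 percentage points higher from compound 3 to compound 4 (beyond the scatter) is upward but uncertain in size.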

Compound 4, percent growth inhibition at one concentration: 22.8%
Beside the measured number, compound 4's estimate is 22.2 percentage points above it, within the range that was stated.
By their numbers in this assay, from the lowest: compounds 4 and 3 (each within the scatter of the next); then compound 1; then compound 2.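

Chloro in place of hydrogen also lowers the number in this assay (a number 30 percentage points lower from compound 1 to compound 4 (beyond the scatter)), so chloro joins bromo on the low side of the unsubstituted phenyl, while the fluoro of compound 2 goes against this pattern. Exchanging 3-bromophenyl for 4-chlorophenyl alters both the halogen and its place on the ring, yet the two compounds cannot be told apart (a number 6.3 percentage points lower from compound 3 to compound 4 (within the scatter)). Both lie far from the 2-fluorophenyl compound (a number 62.4 percentage points lower from compound 2 to compound 4 (beyond the scatter)), so at this position, a fluoro and a chloro or bromo are not interchangeable. Nothing measured here accounts for these differences.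

The compounds shown never vary the halogen while holding its place on the ring fixed, so it remains open which of the two governs the read-out. Also open, on these data alone, is how a ring carrying a methoxy group or an amine would behave.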